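The source may hold more compounds than are shown below. What is called first, only, known or untested is meant among the compounds shown, and "the series" means these compounds.

Measured so far:
compound 1 `O=C1C=C(NCc2ccccc2)C(=O)c2c1nc1n2[C@H]2OC[C@@H](O)[C@H]2OC1` — > 8000 nM
compound 2 `Cc1ccc(NC2=CC(=O)c3c(nc4n3[C@H]3OC[C@@H](O)[C@H]3OC4)C2=O)cc1` — > 4000 nM
compound 3 `CCOc1ccc(NC2=CC(=O)c3c(nc4n3[C@H]3OC[C@@H](O)[C@H]3OC4)C2=O)cc1` — > 4000 nM

In a functional assay on ECa-109 cells for inhibition, with ECa-109 cell line (Homo sapiens) as the target, read by sulforhodamine B assay (a higher number here means a weaker inhibitor, a lower number a stronger inhibitor), compound 1 sits at a limit of the assay, not at a number. The two further values are limits as well, so compound 1 cannot be placed against them in order. Compound 4 `COc1cccc(NC2=CC(=O)c3nc4n(c3C2=O)[C@H]2OC[C@@H](O)[C@H]2OC4)c1` differs from compound 1 by 3-methoxyphenyl in place of benzyl on an amine nitrogen. Among the measured compounds shown here, the one measured step, a step that the two limits leave unreadable from compound 2 to compound 3, is unreadable, since both ends are limits: the limit of > 4000 nM in this assay, at which 2 of the 3 values shown sit. Compound 1 stands at the other limit: the limit of > 8000 nM in this assay, at which 1 of the 3 values shown sits. No readable step bears on the change, so no direction beyond the scatter can be expected. Compound 4 is therefore expected to remain near the limits, at an estimated 8000 nM (range 3000 nM to 20000 nM), a step of a number no higher from compound 1 to compound 4 (the limit leaves the size open) from compound 1 that is only an expectation.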

Compound 4, half-maximal inhibitory concentration: 7620 nM
Compound 4: the middle estimate sits 1.0-fold (0.02 log units) above what was measured; measured number inside the range.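

In this assay, compound 4 gives the series its first number rather than a limit, so (3-methoxyphenyl)amino in place of benzylamino keeps measurable activity in this position. The change gives an at least 1.0-fold lower number from compound 1 to compound 4 (0.02 log units; that floor lies within the scatter), so no gain beyond the scatter can be claimed from this pair. Its full size stays open because compound 1 stands at a limit: the limit of > 8000 nM in this assay, at which 1 of the 4 values shown sits.

The step between the two limit compounds still cannot be read. Also open, as far as these compounds go, is whether a hexyl chain or an aminoethyl group on this amine nitrogen would give a clearly lower number.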